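The source may report more compounds than this note shows. Statements on the series, on what has been measured and on what is new or still open speak of the compounds shown alone.

Measured in a functional assay on HCT-116 cells (Homo sapiens) for antiproliferative activity, read by CCK-8 assay, with a stated time of 72 h; on this read-out lower numbers stand for stronger inhibition and higher numbers for weaker inhibition:
- compound 1 `Nc1ccccc1NC(=O)c1ccc(Cn2cnc3c(NCc4ccccc4)nc(Cl)nc32)cc1`: 1060 nM
- compound 2 `CC1CCN(c2nc(Cl)nc3c2ncn3Cc2ccc(C(=O)Nc3ccccc3N)cc2)CC1`: 950 nM

Going by the values given here, compound 2, at 950 nM, lies within the scatter of compound 1, and these are the only two numbers available. Compound 3 `CN1CCN(c2nc(Cl)nc3c2ncn3Cc2ccc(C(=O)Nc3ccccc3N)cc2)CC1` differs from compound 2 by one change: 4-methylpiperazin-1-yl in place of 4-methylpiperidin-1-yl on an aromatic carbon. Among the compounds with values here, only one measured step bears on this, a 1.1-fold lower number from compound 1 to compound 2 (0.05 log units; within the scatter), which replaced benzylamino on that same carbon and stayed within the scatter. No step beyond the scatter is therefore expected in this assay. The expected step is a 1.1-fold lower number from compound 2 to compound 3 (0.02 log units; within the scatter). Compound 3 is estimated at 900 nM, with an expected range from 400 nM to 2000 nM.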

Compound 3, half-maximal inhibitory concentration: 310 nM
Estimate against measurement, compound 3: 2.9-fold (0.46 log units) above; the whole stated range lies above it.
By their numbers in this assay, from the lowest: compound 3; then compounds 2 and 1 (each within the scatter of the next).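

Unlike the earlier change at this aromatic carbon, which stayed within the scatter, 4-methylpiperazin-1-yl brings a 3.1-fold lower number from compound 2 to compound 3 (0.49 log units; beyond the scatter) in this assay and also a 3.4-fold lower number from compound 1 to compound 3 (0.53 log units; beyond the scatter) when it replaces benzylamino. The group here therefore does affect the number, and between the two six-membered rings, which have equal heavy-atom counts, a second ring nitrogen in place of a carbon is enough to produce the step. Nothing available explains this step. Open, on these data alone, is whether piperazin-1-yl without the methyl or morpholin-4-yl on this carbon would give a similar number. Also open, as far as these compounds go, is whether the step would hold with an amine in place of the chloro group.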